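This account rests on a few compounds, and the source may have more. Where it says the series, first, only, none or still open, it means among the compounds named here.

Compound 1 `Cc1ccccc1C(=O)Nc1cccc(-c2oc3cc(-c4ccc(F)cc4)ccc3c(=O)c2O)c1`: in a functional assay on HeLa cells (Homo sapiens) for antiproliferative activity, read by CCK-8 assay, with a stated time of 72 h (on this read-out lower numbers stand for stronger inhibition and higher numbers for weaker inhibition), compound 1 gives 11900 nM.
Compound 2 `O=C(Nc1cccc(-c2oc3cc(-c4ccc(F)cc4)ccc3c(=O)c2O)c1)c1ccc(C(F)(F)F)cc1`: compound 2 gives 17400 nM.
Compound 3 `Cc1cc(C)cc(C(=O)Nc2cccc(-c3oc4cc(-c5ccc(F)cc5)ccc4c(=O)c3O)c2)c1`: compound 3 gives 5540 nM.

Compound 2 holds the highest number of the three, with a 1.5-fold higher number from compound 1 to compound 2 (0.17 log units; within the scatter) lying within the scatter and a 3.1-fold lower number from compound 2 to compound 3 (0.50 log units; beyond the scatter) reaching beyond it. Compound 4 `N#Cc1ccc(C(=O)Nc2cccc(-c3oc4cc(-c5ccc(F)cc5)ccc4c(=O)c3O)c2)cc1` differs from compound 2 in one place: cyano in place of trifluoromethyl on an aromatic carbon. The measured steps each swap the whole ring attached to the carbonyl, so none exchanges one group for another at the same place; they show that such swaps move the number only modestly, as a 2.1-fold lower number from compound 1 to compound 3 (0.33 log units; beyond the scatter) does. A step of similar or smaller size in this assay is expected for compound 4, in either direction. Compound 4 is therefore estimated at 14000 nM, range 5000 nM to 40000 nM, which means a 1.2-fold lower number from compound 2 to compound 4 (0.09 log units; within the scatter) is expected.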

Compound 4, half-maximal inhibitory concentration: 23300 nM
Compound 4: the middle estimate sits 1.7-fold (0.22 log units) below what was measured; measured number inside the range.
By their numbers in this assay, from the lowest: compound 3; then compounds 1, 2 and 4 (each within the scatter of the next).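

In this assay, putting cyano in place of trifluoromethyl at one and the same aromatic carbon gives a 1.3-fold higher number from compound 2 to compound 4 (0.13 log units; within the scatter) and so does not separate the two groups at this place. The swap of the whole ring gives a 2.0-fold higher number from compound 1 to compound 4 (0.29 log units; within the scatter) and likewise separates nothing, while only the 3,5-dimethylphenyl ring stands apart, with a 4.2-fold higher number from compound 3 to compound 4 (0.62 log units; beyond the scatter). Nothing measured here gives a reason for these results. Going by these compounds, whether an amine or a carboxylic acid on this same carbon would also leave the number unchanged remains open.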